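The source may hold more compounds than are shown below. What is called first, only, known or untested is meant among the compounds shown, and "the series" means these compounds.

Compound 1 `Cc1cc(Nc2cc(-c3ccccc3)[nH]n2)n2nc(SCCCc3ccccc3)nc2n1` is one of three close analogues that share a core and differ only in the group on a saturated chain carbon bound to a sulfur. In an ADME assay on GES1 cells (Homo sapiens) for inhibition, read by MTT assay, with a stated time of 72 h (a higher number here means a weaker inhibitor, a lower number a stronger inhibitor), compound 1 gives 40200 nM, the highest of the three numbers. Compound 2 `Cc1cc(Nc2cc(-c3ccccc3)[nH]n2)n2nc(SCc3cccc4ccccc34)nc2n1` gives 36300 nM in this assay, and compound 3 `COc1ccc(CSc2nc3nc(C)cc(Nc4cc(-c5ccccc5)[nH]n4)n3n2)cc1` gives 28200 nM. The steps of a 1.1-fold lower number from compound 1 to compound 2 (0.04 log units; within the scatter) and a 1.4-fold lower number from compound 1 to compound 3 (0.15 log units; within the scatter) both stay within the scatter, as does a 1.3-fold lower number from compound 2 to compound 3 (0.11 log units; within the scatter). Compound 4 `Cc1cc(Nc2cc(-c3ccccc3)[nH]n2)n2nc(SCC(=O)c3ccccc3)nc2n1` carries benzoyl in place of phenethyl on a saturated chain carbon bound to a sulfur. Exchanging the aromatic group at this position has so far left this assay unchanged, so no step beyond the scatter is expected, a 1.1-fold lower number from compound 1 to compound 4 (0.06 log units; within the scatter). Compound 4 is therefore estimated at 35000 nM, with a range from 15000 nM to 80000 nM.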

Compound 4, half-maximal inhibitory concentration: 33300 nM
Beside the measured number, compound 4's estimate is 1.1-fold (0.02 log units) above it, and the stated range covers the measured number.
By their numbers in this assay, from the lowest: compounds 3, 4, 2 and 1 (each within the scatter of the next).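

Benzoyl puts a carbonyl on the saturated chain carbon bound to a sulfur, and in this assay this new kind of link to the aromatic ring leaves the number in the same band as phenethyl (a 1.2-fold lower number from compound 1 to compound 4 (0.08 log units; within the scatter)), 4-methoxyphenyl (a 1.2-fold higher number from compound 3 to compound 4 (0.07 log units; within the scatter)) and naphthalen-1-yl (a 1.1-fold lower number from compound 2 to compound 4 (0.04 log units; within the scatter)). So at this position, the carbonyl and its hydrogen-bond acceptor shift nothing that can be told from scatter. Nothing available explains why. As far as these compounds go, all four compounds carry an aromatic ring here, so a plain ethyl chain, an amine or a carboxylic acid in its place remains open.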